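The compounds below may be only part of what the source reports. "The series", "measured", "known", "first", "only" and "open" are said of these compounds alone.

Measured in a functional assay on MDA-MB-231 cells (Homo sapiens) for antiproliferative activity, read by MTT assay, with a stated time of 48 h; on this read-out lower numbers stand for stronger inhibition of growth and higher numbers for weaker inhibition of growth:
Compound 1 `COC(=O)N1N=C(c2ccc(OC)cc2)CC1c1cc(OC)c(OC)c(OC)c1`: 1990 nM
Compound 2 `CCOC(=O)N1N=C(c2ccc(OC)cc2)CC1c1cc(OC)c(OC)c(OC)c1`: 2660 nM
Compound 3 `COc1ccc(C2=NN(C(=O)OCc3ccccc3)C(c3cc(OC)c(OC)c(OC)c3)C2)cc1`: > 10000 nM, a limit of the assay and not a number

Compound 1 stands level with compound 2: a 1.3-fold higher number from compound 1 to compound 2 (0.13 log units; within the scatter). Against the limit of compound 3, the steps are an at least 5.0-fold higher number from compound 1 to compound 3 (0.70 log units; beyond the scatter) and an at least 3.7-fold higher number from compound 2 to compound 3 (0.57 log units; beyond the scatter).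

Compound 4 `COC(=O)N1N=C(c2cccc(Cl)c2)CC1c1cc(OC)c(OC)c(OC)c1` keeps the core of compound 1 and its methoxycarbonyl group, but has 3-chlorophenyl in place of 4-methoxyphenyl on a carbon with a double bond to nitrogen. For the measured compounds named here, no measured step touches this place, since all three alter only the methoxycarbonyl end. They give no direct size for this change. Going by the values given here, the only indirect guide is a single change that gave an at least 5.0-fold higher number from compound 1 to compound 3 (0.70 log units; beyond the scatter), so a step beyond the scatter is possible. With little certainty, a modest step towards weaker inhibition of growth is expected in this assay, and the estimated step is a 2.5-fold higher number from compound 1 to compound 4 (0.40 log units; beyond the scatter). For compound 4 the estimated value is 5000 nM, with an expected range of 1500 nM to 10000 nM.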

Compound 4, concentration for 50% growth inhibition: 110 nM
For compound 4 the middle estimate is 45-fold (1.66 log units) above the measured one, and the stated range ends above it.
By their numbers in this assay, from the lowest: compound 4; then compounds 1 and 2 (each within the scatter of the next). At a limit, above all of these: compound 3.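

In this assay, 3-chlorophenyl in place of 4-methoxyphenyl on a carbon with a double bond to nitrogen gives an 18-fold lower number from compound 1 to compound 4 (1.26 log units; beyond the scatter), so this place can carry a large step towards stronger inhibition of growth. For the compounds shown here, the earlier steps, all at the methoxycarbonyl end, showed no step in that direction beyond the scatter, which makes this the first change to give such a gain. Nothing measured here accounts for the size of this step.

On these data alone, a single step cannot separate the departure of the methoxy group from the arrival of the chlorine, so the share of each stays open. Also open, as far as these compounds go, are how a plain phenyl, a bromophenyl or an aminophenyl would behave at this place, and whether the gain carries over to the ethoxycarbonyl end of compound 2.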